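Notes on a methyl addition to the distal phenyl ring

The source may hold more compounds than are shown below. What is called first, only, known or untested is meant among the compounds shown, and "the series" means these compounds.

Two compounds of the series have numbers in a functional assay on HT-29 cells (Homo sapiens) for cytotoxicity, read by MTT assay, with a stated time of 72 h; on this read-out higher numbers stand for weaker inhibition and lower numbers for stronger inhibition. Compound 1 `COc1cc2c(Oc3ccc(NC(=O)c4cc(-c5ccccc5)ccn4)cc3F)ccnc2cc1OCCCN1CCCCC1` gives 270 nM. Compound 2 `COc1cc2c(Oc3ccc(NC(=O)c4nccc(-c5ccccc5)n4)cc3F)ccnc2cc1OCCCN1CCCCC1` gives 260 nM; the step of a 1.0-fold lower number from compound 1 to compound 2 (0.02 log units; within the scatter) shows that the two compounds stand within the scatter of each other, so no order between them can be read from the numbers. Compound 3 `COc1cc2c(Oc3ccc(NC(=O)c4nccc(-c5ccc(C)cc5)n4)cc3F)ccnc2cc1OCCCN1CCCCC1` differs from compound 2 by methyl in place of hydrogen on an aromatic carbon. For the measured compounds named here, no measured step in this assay bears on this change: the only step known, from compound 1 to compound 2, concerns the ring bonded to the carbonyl, not the phenyl ring, and it was itself within the scatter. With nothing to point in either direction, the expected step of a 1.0-fold lower number from compound 2 to compound 3 (0.02 log units; within the scatter) is none beyond the scatter. Compound 3 is therefore estimated at 250 nM, with a range from 90 nM to 700 nM.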

Compound 3, half-maximal inhibitory concentration: 620 nM
Compound 3: the middle estimate sits 2.5-fold (0.39 log units) below what was measured; the range from low to high includes it.
By their numbers in this assay, from the lowest: compounds 2 and 1 (each within the scatter of the next); then compound 3.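

In this assay the change from phenyl to 4-methylphenyl gives a 2.4-fold higher number from compound 2 to compound 3 (0.38 log units; beyond the scatter) and so is the first step among these compounds to lie beyond the scatter. The distal phenyl ring therefore responds to substitution at the position para to a large group: one added carbon moves the number towards weaker inhibition, a modest step, whereas the exchange of 4-phenylpyridin-2-yl for 4-phenylpyrimidin-2-yl gave no readable difference. No available measurement accounts for this step.

From the compounds shown here alone, whether a fluorine atom, a methoxy group or a dimethylamino group at the same position would stay near compound 2 or fall near compound 3 remains open. Also open, going by these compounds, is whether methyl elsewhere on the phenyl ring, or the same methyl on compound 1, would give a step of similar size.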